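Amide variation on the shared core: toward compound 3

A few compounds are considered here, and "the series" means these few. Any claim that something is new, unique, unknown or untested is made for them only; others in the source may bear on it.

Measured so far:
compound 1 `CC(=O)N1CC2CC(C1)N2` — 610 nM in an assay on CHO cells for displacement of a labelled ligand from Neuronal acetylcholine receptor; alpha3/alpha6/beta2/beta3 (Homo sapiens), read by scintillation counting; on this read-out higher numbers stand for weaker inhibition and lower numbers for stronger inhibition
compound 2 `CC(C)C(=O)N1CC2CC(C1)N2` — 580 nM

Compound 2 holds the lower of the two numbers, but compound 1 stands within the scatter of it, so no order can be read between them. Compound 3 `O=C(C1CCC1)N1CC2CC(C1)N2` differs from compound 2 by cyclobutyl in place of isopropyl on a carbonyl carbon. Within the data shown here, the only step bearing on this position, a 1.1-fold lower number from compound 1 to compound 2 (0.02 log units; within the scatter), stayed within the scatter, so the expected change is a 1.1-fold lower number from compound 2 to compound 3 (0.02 log units; within the scatter), with nothing beyond the scatter. Compound 3 is therefore estimated at 550 nM, in the range 250 nM to 1200 nM.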

Compound 3, inhibition constant: 240 nM
For compound 3 the middle estimate is 2.3-fold (0.36 log units) above the measured one; measured number outside the range, below it.
By their numbers in this assay, from the lowest: compound 3; then compounds 2 and 1 (each within the scatter of the next).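

The carbonyl carbon position is not indifferent to the group it carries: in this assay cyclobutyl gives a 2.4-fold lower number from compound 2 to compound 3 (0.38 log units; beyond the scatter) and a 2.5-fold lower number from compound 1 to compound 3 (0.41 log units; beyond the scatter), both modest, whereas methyl and isopropyl could not be told apart. This change adds one carbon and a ring together, so the two contributions cannot be separated here. No available evidence bears on the origin of this step.

Open, as far as these compounds go, is whether cyclopropyl, cyclopentyl or a longer chain such as n-butyl would extend this step or reverse it.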